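This account rests on a few compounds, and the source may have more. Where it says the series, first, only, none or still open, it means among the compounds named here.

In an ADME assay on microsomes from liver (Homo sapiens) for metabolic stability, read by LC-MS, using NADPH, with a stated time of 30 min, tested at 1 uM (on this read-out higher numbers stand for a more stable compound and lower numbers for a less stable compound), compound 1 (`C=CC(=O)Nc1cc(Nc2ncc(F)c(Nc3ccccc3S(=O)(=O)N(C)C)n2)c(OC)cc1N(C)CCN(C)C`) gives 9% remaining and compound 2 (`C=CC(=O)Nc1cc(Nc2ncc(Cl)c(Nc3ccccc3S(=O)(=O)C(C)C)n2)c(OC)cc1N(C)CCN(C)C`) gives 16% remaining. These two numbers lie within the usual scatter of each other, so compound 2 stands level with compound 1, and little of either survives the incubation.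

Compound 3 (`C=CC(=O)Nc1cc(Nc2ncc(F)c(Nc3ccccc3S(=O)(=O)C(C)C)n2)c(OC)cc1N(C)CCN(C)C`) differs from compound 2 at one place: fluoro in place of chloro on an aromatic carbon. Within the data shown here, no measured pair shows this exchange on its own. Among the measured compounds shown here, compound 1 also carries fluoro, though it differs elsewhere too, and it gives 9% in this assay as its only guide to a fluoro compound. A shift no larger than the usual scatter is therefore expected. The estimated a number 3 percentage points lower from compound 2 to compound 3 (within the scatter) is a slight fall. For compound 3 the expected value is 13% with an estimated range from 5% to 25% on this read-out.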

Compound 3, percent of the compound remaining: 26%
The estimate for compound 3 lay 13 percentage points below the measured number; the whole stated range lies below it.
By their numbers in this assay, from the lowest: compounds 1, 2 and 3 (each within the scatter of the next, the first and the last beyond it).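

In this assay, fluoro in place of chloro on an aromatic carbon, two atoms from the ring nitrogen, gives a number 10 percentage points higher from compound 2 to compound 3 (within the scatter), so the two halogens cannot be told apart at this position on this read-out. The other single change, isopropyl in place of dimethylamino on a sulfonyl sulfur, gives a number 17 percentage points higher from compound 1 to compound 3 (beyond the scatter), a modest step and the only one here that clears the scatter. No measurement that would explain either step is available.

On these data alone, whether a hydrogen or a methyl group at the halogen's place, or a cyclopropyl group or a morpholine on the sulfonyl sulfur, would shift the number remains open. Also open, as far as these compounds go, is whether isopropyl in place of dimethylamino gives a similar step with chloro rather than fluoro on the ring.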